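Pyridin-2-yl to pyridin-4-yl at the aromatic nitrogen

This account rests on a few compounds, and the source may have more. Where it says the series, first, only, none or still open, it means among the compounds named here.

Three compounds share one core and differ only in the group on the saturated chain carbon bound to an aromatic nitrogen. In an assay on isolated protein for inhibition of Gonadotropin-releasing hormone receptor (Rattus norvegicus) (on this read-out higher numbers stand for weaker inhibition and lower numbers for stronger inhibition), compound 1 `CCCn1c(SCc2cc([N+](=O)[O-])ccc2OC)nc2cc(NC(=O)NC(C)(C)C)ccc21` gives 120 nM, compound 2 `CCCCCn1c(SCc2cc([N+](=O)[O-])ccc2OC)nc2cc(NC(=O)NC(C)(C)C)ccc21` gives 880 nM, and compound 3 `COc1ccc([N+](=O)[O-])cc1CSc1nc2cc(NC(=O)NC(C)(C)C)ccc2n1Cc1ccccn1` gives 670 nM. The step of a 7.3-fold higher number from compound 1 to compound 2 (0.87 log units; beyond the scatter) and the step of a 5.6-fold higher number from compound 1 to compound 3 (0.75 log units; beyond the scatter) both move away from compound 1, while the step of a 1.3-fold lower number from compound 2 to compound 3 (0.12 log units; within the scatter) stays within the scatter. Compound 3 thus stands second highest of the three numbers, close to compound 2 and well apart from compound 1.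

Compound 4 `COc1ccc([N+](=O)[O-])cc1CSc1nc2cc(NC(=O)NC(C)(C)C)ccc2n1Cc1ccncc1` differs from compound 3 by pyridin-4-yl in place of pyridin-2-yl on a saturated chain carbon bound to an aromatic nitrogen. Within the data shown here, no measured step moves the nitrogen within the pyridine ring; the steps seen so far only swap an alkyl chain for pyridin-2-yl. There is therefore no basis for expecting a step beyond the scatter in this assay, in either direction. Compound 4 is estimated at 700 nM, with a range from 250 nM to 2000 nM, which means an expected step of a 1.0-fold higher number from compound 3 to compound 4 (0.02 log units; within the scatter).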

Compound 4, half-maximal inhibitory concentration: 240 nM
Compound 4: the middle estimate sits 2.9-fold (0.46 log units) above what was measured; the measured number lies below the stated range.
By their numbers in this assay, from the lowest: compounds 1 and 4 (each within the scatter of the next); then compounds 3 and 2 (each within the scatter of the next).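

In this assay, the location of the ring nitrogen matters at this position: with the same atoms and the same counts, pyridin-4-yl in place of pyridin-2-yl gives a 2.8-fold lower number from compound 3 to compound 4 (0.45 log units; beyond the scatter). Pyridin-4-yl in place of butyl gives a 3.7-fold lower number from compound 2 to compound 4 (0.56 log units; beyond the scatter), while pyridin-4-yl in place of ethyl gives a 2.0-fold higher number from compound 1 to compound 4 (0.30 log units; within the scatter), so a pyridine on this carbon does not always separate from the short chain of compound 1. Nothing at hand bears on why the two pyridines differ.

From the compounds shown here alone, whether pyridin-3-yl or a plain phenyl ring on this carbon would fall with compound 3 or with compound 4 remains open. Also open, going by these compounds, is how an amine or a carboxylic acid at the end of the chain would read in this assay.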